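The compounds below may be only part of what the source reports. "The series", "measured", "known", "first", "only" and "open" are said of these compounds alone.

Measured compounds and their values in an assay on membranes from brain for binding affinity to adenosine receptor A1 (Rattus norvegicus), read by radioligand binding, tested at 20 uM; on this read-out lower numbers stand for less inhibition and higher numbers for more inhibition at the one concentration tested (going by the name of the read-out):

Compound 1, `Cn1c(=O)[nH]c2c(cnn2-c2cccc(Br)c2)c1=N`, gives 40%.
Compound 2, `Cn1c(=O)[nH]c2c(cnn2-c2cccc(Cl)c2)c1=N`, gives 53%.
Compound 3, `Cn1c(=O)[nH]c2c(cnn2-c2ccccc2Cl)c1=N`, gives 7%.

The three share a core and differ only in the halogen on the phenyl ring and in where it sits. Compound 1 differs from compound 2 in one place, (bromo in place of chloro on an aromatic carbon), and this change brings a number 13 percentage points lower from compound 2 to compound 1 (beyond the scatter). Compound 3 has the same atoms as compound 2 joined differently; the difference between the two cores is not broken down here. In this assay compound 3 stands lowest of the three, and both other compounds lie beyond the scatter above it.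

Compound 4, `Cn1c(=O)[nH]c2c(cnn2-c2ccccc2Br)c1=N`, has not yet been measured in this assay. It differs from compound 3 in one place, (bromo in place of chloro on an aromatic carbon). Among the measured compounds shown here, this is the same kind of change as the one from compound 2 to compound 1, though not the same: there the bromo entered meta to a large group, here it enters ortho to a large group. Compound 4 is expected to show a number 2 percentage points lower from compound 3 to compound 4 (within the scatter), a step that rests on the modest drop seen in a number 13 percentage points lower from compound 2 to compound 1 (beyond the scatter), applied to the low starting point of compound 3. Since compound 3 already gives 7%, a further drop can only be small, and compound 4 is estimated at 5%, between 0% and 25%.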

Compound 4, a percentage reported as inhibition, at one concentration (the size of the read-out at that concentration, not a potency): 6%
Compound 4: the middle estimate sits 1 percentage points below what was measured; the range from low to high includes it.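

In this assay the exchange of chloro for bromo on an aromatic carbon, ortho to a large group, comes to a number 1 percentage points lower from compound 3 to compound 4 (within the scatter), so at this place the two halogens give values that cannot be told apart. Set beside the earlier exchange, the two steps look different at first sight but do not differ beyond what repeated measurements would give, and the change therefore carries over from one core to the other without a detectable difference: the same change on two cores in this assay, a number 13 percentage points lower (beyond the scatter) from compound 2 to compound 1 and a number 1 percentage points lower (within the scatter) from compound 3 to compound 4, 12 percentage points apart, within the scatter of two such steps This does not show that the change has a fixed size across the series, since it rests on two pairs only, and compound 3 at 7% and compound 4 at 6% both lie near the bottom of the read-out, where a single tested concentration says little about how far a step could reach.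

The compounds shown carry only chloro or bromo on the phenyl ring, so how the read-out responds to a methoxy group, an amine or a carboxylic acid there remains open. Also open, on these data alone, is what a longer chain in place of the methyl on the shared core would do, and whether the exchange of halogens behaves the same way at other places on the ring.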